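The source may hold more compounds than are shown below. What is called first, only, known or untested is meant among the compounds shown, and "the series" means these compounds.

Measured so far in an assay on HL-60 cells for agonist activity at vitamin D3 receptor (Homo sapiens), read by microscopy, with a stated time of 96 h; on this read-out lower numbers stand for an effect already at smaller amounts and higher numbers for an effect only at larger amounts of compound:
compound 1, `CCn1c(C(=O)NCC(OC)OC)ccc1C(CC)(CC)c1ccc(OCC(=O)C(C)(C)C)c(C)c1`: 130 nM
compound 2, `C#CC(C)OC(=O)c1ccc(C(CC)(CC)c2ccc(OCC(=O)C(C)(C)C)c(C)c2)n1CC`: 210 nM
compound 3, `CCOc1ccc(NC(=O)c2ccc(C(CC)(CC)c3ccc(OCC(=O)C(C)(C)C)c(C)c3)n2CC)cc1`: > 50000 nM

The value of compound 3 is a limit of the assay and not a number (the limit of > 50000 nM in this assay, at which 1 of the 3 values shown sits). Compound 1 and compound 2 lie close together: a 1.6-fold higher number from compound 1 to compound 2 (0.21 log units; within the scatter). The two other steps are large: an at least 380-fold higher number from compound 1 to compound 3 (2.58 log units; beyond the scatter), and an at least 230-fold higher number from compound 2 to compound 3 (2.37 log units; beyond the scatter).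

Compound 4, `CCOC(=O)c1ccc(OC(=O)c2ccc(C(CC)(CC)c3ccc(OCC(=O)C(C)(C)C)c(C)c3)n2CC)cc1`, differs from compound 3 in one place: 4-(ethoxycarbonyl)phenoxy in place of (4-ethoxyphenyl)amino on a carbonyl carbon. Two things bear on it. Exchanging an amino group for an oxy group on the carbonyl carbon stayed within the scatter in the step of a 1.6-fold higher number from compound 1 to compound 2 (0.21 log units; within the scatter). The six-membered aromatic ring on that carbonyl carbon, however, came in with the large losses an at least 380-fold higher number from compound 1 to compound 3 (2.58 log units; beyond the scatter) and an at least 230-fold higher number from compound 2 to compound 3 (2.37 log units; beyond the scatter), and compound 4 keeps such a ring. On this ground compound 4 is expected to stay weak in this assay, with a fair chance of another limit. The estimate for compound 4 is 15000 nM, in the range 1000 nM to 50000 nM. The expected step is an at least 3.3-fold lower number from compound 3 to compound 4 (0.52 log units; beyond the scatter).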

Compound 4, half-maximal effective concentration: 45600 nM
For compound 4 the middle estimate is 3.0-fold (0.48 log units) below the measured one; the range from low to high includes it.
By their numbers in this assay, from the lowest: compounds 1 and 2 (each within the scatter of the next); then compound 4. At a limit, above all of these: compound 3.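

In this assay, compound 4 shows that the large loss is not tied to an amide nitrogen: with 4-(ethoxycarbonyl)phenoxy on the carbonyl carbon, the steps are a 220-fold higher number from compound 2 to compound 4 (2.34 log units; beyond the scatter) and a 350-fold higher number from compound 1 to compound 4 (2.55 log units; beyond the scatter). Between the two compounds with a six-membered aromatic ring in this group, only a floor can be read, an at least 1.0-fold lower number from compound 3 to compound 4 (0.04 log units; that floor lies within the scatter), so this exchange shows no resolved change. Compound 3 stands at a limit of the assay and not at a number: the limit of > 50000 nM in this assay, at which 1 of the 4 values shown sits.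

Open, on these data alone, is whether a cyclohexyl ester or a benzyl ester on the same carbonyl carbon would stay close to compound 1 and compound 2 or share the loss. Also open, as far as these compounds go, is how an unsubstituted phenyl ester or a 4-carboxyphenyl ester would compare with compound 4.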